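Methyl in Place of Hydrogen on the Benzoxazine Ring

A few compounds are considered here, and "the series" means these few. Any claim that something is new, unique, unknown or untested is made for them only; others in the source may bear on it.

Measured so far:
compound 1 `COc1cc2c(c(OC)c1)OCN(c1ccc3oc(-c4ccccc4)cc(=O)c3c1)C2` gives 60% in a functional assay on MCF7 cells (Homo sapiens) for inhibition, read by MTT assay, with a stated time of 48 h, tested at 15 ug/mL; a higher number here means more inhibition of growth at the concentration tested, a lower number less inhibition of growth
compound 3 `COc1cccc2c1OCN(c1ccc3oc(-c4ccccc4)cc(=O)c3c1)C2` gives 54% in this assay
compound 2 `O=c1cc(-c2ccccc2)oc2cc(N3COc4ccccc4C3)ccc12` gives 3.89% in this assay

Compound 2 stands lowest of the three numbers; compound 3 and compound 1 both give higher values, and both gaps are beyond the scatter. The new compound 4 `Cc1cccc2c1OCN(c1ccc3c(=O)cc(-c4ccccc4)oc3c1)C2` differs from compound 2 by methyl in place of hydrogen on an aromatic carbon. For the measured compounds named here, only one measured step involves the same position: a number 6 percentage points lower from compound 1 to compound 3 (within the scatter), which shows that removing a methoxy from that carbon leaves the number essentially unchanged. Going by the values given here, no measured step tells what a methyl does there. The values of compound 2 and compound 3 show that a methoxy on that carbon goes with a far higher number, but a methyl is a different group, so a rise of the same size cannot be assumed. A moderate rise is expected, a number 31.1 percentage points higher from compound 2 to compound 4 (beyond the scatter), with wide uncertainty. Compound 4 is therefore estimated at 35%, between 5% and 65%.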

Compound 4, percent growth inhibition at one concentration: 54.9%
The estimate for compound 4 lay 19.9 percentage points below the measured number, and the stated range covers the measured number.
By their numbers in this assay, from the lowest: compound 2; then compounds 3, 4 and 1 (each within the scatter of the next).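

In this assay, a single methyl in place of hydrogen on this aromatic carbon, ortho to a fused ring and meta to a fused ring, gives a number 51 percentage points higher from compound 2 to compound 4 (beyond the scatter) and counts as a large step. For the compounds shown here, the only earlier one-place step, a number 6 percentage points lower from compound 1 to compound 3 (within the scatter) in the same assay, showed no change of this kind, so this is the first evidence that one small group on the ring can move the number this far. Nothing available explains why this methyl has so large an effect.

What the compounds shown leave open is whether this rise is particular to methyl or would also appear with an ethyl, a chlorine, an amine or a carboxylic acid on the same carbon. They also leave open how a methyl would act on the other carbons of that ring.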